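Pentyl for methylsulfonyl on the ring nitrogen of compound 1

A few compounds are considered here, and "the series" means these few. Any claim that something is new, unique, unknown or untested is made for them only; others in the source may bear on it.

Measured so far:
compound 1, `Cc1ccc(-c2c3c(nc(C)c2C(OC(C)(C)C)C(=O)O)CCN(S(C)(=O)=O)C3)cc1`, > 40000 nM
compound 2, `Cc1nc2c(c(-c3cc(F)c4c(c3C)CCCO4)c1[C@H](OC(C)(C)C)C(=O)O)CN(CCCc1cccc(F)c1)CC2`, > 40000 nM

Compound 1, `Cc1ccc(-c2c3c(nc(C)c2C(OC(C)(C)C)C(=O)O)CCN(S(C)(=O)=O)C3)cc1`, was tested in an ADME assay on MT2 cells (Homo sapiens) for cytotoxicity, read by XTT assay, with a stated time of 4 days; a lower number here means that less compound is tolerated, a higher number that more compound is tolerated. In this assay compound 1 gives > 40000 nM, which is a limit of the assay and not a number. Compound 2, `Cc1nc2c(c(-c3cc(F)c4c(c3C)CCCO4)c1[C@H](OC(C)(C)C)C(=O)O)CN(CCCc1cccc(F)c1)CC2`, also gives > 40000 nM in this assay, again a limit rather than a number. Both values thus sit at the same point: the limit of > 40000 nM in this assay, at which 2 of the 2 values shown sit. Going by the values given here, no step between measured compounds that differ in one place is available here, so the two values show only that neither compound reached a measurable half-maximal cytotoxic concentration.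

Compound 3, `CCCCCN1CCc2nc(C)c(C(OC(C)(C)C)C(=O)O)c(-c3ccc(C)cc3)c2C1`, differs from compound 1 at one place: pentyl in place of methylsulfonyl on an amine nitrogen in a ring. Since compound 2 carries a longer substituent on the same ring nitrogen and still gives only a limit, a step from compound 1 to compound 3 that goes beyond the scatter is not expected, though an alkyl chain in place of the sulfonyl group leaves some room for a lower value. Compound 3 is therefore expected to give 40000 nM in this assay, within a range of 15000 nM to 100000 nM, which means an estimated step of a number no higher from compound 1 to compound 3 (the limit leaves the size open).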

Compound 3, half-maximal cytotoxic concentration: > 40000 nM
Compound 3: only a limit was reported; the forecaster's own chance of this, stated with the estimate: 65%; the middle value sits exactly at the limit.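

In this assay compound 3 gives > 40000 nM as a limit of the assay and not a number. Going by these compounds alone, compound 1 also gives only a limit there, so no step between compound 1 and compound 3 can be read. The compounds shown leave open at what concentration, if any, pentyl or methylsulfonyl on this ring nitrogen would reach half-maximal cytotoxicity.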